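The source may hold more compounds than are shown below. What is called first, only, known or untested is meant among the compounds shown, and "the series" means these compounds.

Compound 1 `Nc1nc(=O)ccn1COCCO` gives > 400 ug/mL in a functional assay (Oryctolagus cuniculus) for inhibition (a lower number here means a stronger inhibitor, a higher number a weaker inhibitor), which is a limit of the assay rather than a number.
Compound 2 `Cc1nc2c(O)nc(N)nc2n1COCCO` gives > 400 ug/mL in this assay, again only a limit.

Both values sit at the limit of > 400 ug/mL in this assay, at which 2 of the 2 values shown sit, so compound 2 stands on a limit and the two compounds cannot be ordered. Compound 3 `Nc1nc(O)c2nc(N3CCCCC3)n(COCCO)c2n1` differs from compound 2 in one place: piperidin-1-yl in place of methyl on an aromatic carbon. Within the data shown here, no measured step connects any pair here; the change in this assay is expected to be none beyond the scatter, a number no higher from compound 2 to compound 3 (the limit leaves the size open). Compound 3 is therefore estimated at 400 ug/mL, within 100 ug/mL to 2000 ug/mL, most likely reported once more only as a limit.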

Compound 3, concentration for 50% inhibition: 333 ug/mL
Compound 3: middle estimate off by 1.2-fold (0.08 log units), on the high side; low and high end bracket the measured number.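

Alone among the three compounds, compound 3 gives a number rather than a limit in this assay, so this aromatic carbon between two ring nitrogen atoms can carry piperidin-1-yl with a measurable result. The change gives an at least 1.2-fold lower number from compound 2 to compound 3 (0.07 log units; that floor lies within the scatter). Its true size cannot be read because compound 2 stands on a limit: the limit of > 400 ug/mL in this assay, at which 2 of the 3 values shown sit.

Going by these compounds, whether the piperidine ring itself matters remains open, as does what an open-chain amine such as dimethylamino or a carboxylic acid at this carbon would give.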